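The source may report more compounds than this note shows. Statements on the series, on what has been measured and on what is new or still open speak of the compounds shown alone.

Working notes on the aryl amine series. Compound 1 `Fc1ccc(Nc2cc(Nc3ccc(Oc4ccncc4-c4cccnc4)c(F)c3)ncn2)cc1F` in a functional assay on MKN-45 cells (Homo sapiens) for cytotoxicity, read by MTT assay, with a stated time of 72 h (on this read-out higher numbers stand for weaker inhibition and lower numbers for stronger inhibition), gives 80 nM. Compound 3 `Fc1ccc(Nc2cc(Nc3ccc(Oc4ccncc4-c4cccnc4)c(F)c3)ncn2)cc1` gives 160 nM in this assay, and a 2.0-fold higher number from compound 1 to compound 3 (0.30 log units; within the scatter). Compound 2 `Fc1cc(Nc2cc(Nc3ccc(Cl)cc3)ncn2)ccc1Oc1ccncc1-c1cccnc1` gives 240 nM in this assay; this is the highest of the three numbers, with a 3.0-fold higher number from compound 1 to compound 2 (0.48 log units; beyond the scatter) and a 1.5-fold lower number from compound 2 to compound 3 (0.18 log units; within the scatter).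

Compound 4 `COc1cc(Nc2cc(Nc3ccc(Oc4ccncc4-c4cccnc4)c(F)c3)ncn2)cc(OC)c1` is not yet measured. It differs from compound 2 as follows: 3,5-dimethoxyphenyl in place of 4-chlorophenyl on a nitrogen on an aromatic ring. The two measured steps that touch this position are the swap from compound 1 to compound 2 and the swap from compound 2 to compound 3; only the first lies beyond the scatter, and the whole spread of the three numbers is modest. Among the compounds with values here, no measured compound carries a phenyl with two oxygen acceptors, so there is no direct guide to the direction of this change. The expectation is therefore a small step in this assay, more likely downward than upward given that compound 2 sits at the top of the measured range: a 1.6-fold lower number from compound 2 to compound 4 (0.20 log units; within the scatter) is expected. Compound 4 is estimated at 150 nM, within 50 nM to 500 nM.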

Compound 4, half-maximal inhibitory concentration: 1750 nM
Compound 4: the middle estimate sits 12-fold (1.07 log units) below what was measured, and the stated range ends below it.
By their numbers in this assay, from the lowest: compounds 1, 3 and 2 (each within the scatter of the next, the first and the last beyond it); then compound 4.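

In this assay the group on the nitrogen proves far less forgiving than the halogen-bearing phenyl swaps suggested, with 3,5-dimethoxyphenyl giving a 7.3-fold higher number from compound 2 to compound 4 (0.86 log units; beyond the scatter) and an 11-fold higher number from compound 3 to compound 4 (1.04 log units; beyond the scatter) (and a 22-fold higher number from compound 1 to compound 4 (1.34 log units; beyond the scatter)). All three steps run the same way and lie beyond the scatter, which makes compound 4 the weakest of the four compounds here. No measurement at hand accounts for this loss.

On these data alone, this change alters the halogen pattern and introduces two methoxy groups at once, so the part played by the methoxy groups themselves, their number or their placement remains open. Also open, as far as these compounds go, is how this position would respond to a phenyl carrying a single methoxy group, or to one carrying a morpholine or a dimethylamino group.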